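This account rests on a few compounds, and the source may have more. Where it says the series, first, only, none or still open, it means among the compounds named here.

Working notes on the series in a functional assay on MGC-803 cells (Homo sapiens) for inhibition, read by MTT assay, with a stated time of 48 h; on this read-out higher numbers stand for weaker inhibition and lower numbers for stronger inhibition.

Three amides sharing one core have been measured. Compound 1 `C#CC(=O)N(Cc1ccc(OC)c(O)c1)c1cc(OC)c(OC)c(OC)c1` gives 170 nM. Compound 2 `COc1ccc(CN(C(=O)C[Se]C#N)c2cc(OC)c(OC)c(OC)c2)cc1O` gives 270 nM, and compound 3 `COc1ccc(CN(C(=O)CCCCCl)c2cc(OC)c(OC)c(OC)c2)cc1O` gives 540 nM. Compound 3 stands at the highest number of the three: its nearest neighbour is compound 2, with a 2.0-fold higher number from compound 2 to compound 3 (0.30 log units; within the scatter), and its furthest is compound 1, with a 3.2-fold higher number from compound 1 to compound 3 (0.50 log units; beyond the scatter). The remaining pair, a 1.6-fold higher number from compound 1 to compound 2 (0.20 log units; within the scatter), lies within the scatter. All three steps vary only the group on the carbonyl carbon.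

Compound 4 `CCCCC(=O)N(Cc1ccc(OC)c(O)c1)c1cc(OC)c(OC)c(OC)c1` is the next point and differs from compound 3 by hydrogen in place of chloro on a saturated chain carbon, four bonds along the chain from a carbonyl carbon. For the measured compounds named here, no measured step removes a single chlorine from a saturated chain; the three steps on record all swap the whole acyl group, so none of them bears directly on this change. Going by the values given here, the only anchor is compound 3 itself at 540 nM. With no step of this kind in hand, the expectation is for compound 4 to sit near compound 3, with a modest rise in the number judged more likely than a fall, and the estimated step is a 1.7-fold higher number from compound 3 to compound 4 (0.22 log units; within the scatter). Compound 4 is estimated at 900 nM, within a range from 300 nM to 3000 nM.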

Compound 4, half-maximal inhibitory concentration: 66 nM
Compound 4: the middle estimate sits 14-fold (1.13 log units) above what was measured, and the stated range ends above it.
By their numbers in this assay, from the lowest: compound 4; then compounds 1, 2 and 3 (each within the scatter of the next, the first and the last beyond it).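

In this assay, for the compounds shown here, hydrogen in place of chloro on a saturated chain carbon, four bonds along the chain from a carbonyl carbon, is the first change of a single atom, and it gives an 8.2-fold lower number from compound 3 to compound 4 (0.91 log units; beyond the scatter) with the rest of the structure unchanged. The plain butyl group also ranks ahead of both other acyl variants, with a 2.6-fold lower number from compound 1 to compound 4 (0.41 log units; beyond the scatter) against the ethynyl compound and a 4.1-fold lower number from compound 2 to compound 4 (0.61 log units; beyond the scatter) against the selenium-bearing compound, so compound 4 is the most potent of the four and neither ethynyl nor the selenium-bearing group is needed for a low number among these amides. Nothing available accounts for the size of the step on removing the chlorine.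

The compounds shown leave open whether this loss belongs to chlorine alone or would follow from any other atom or group at that place on the chain, such as fluorine, a hydroxyl or an amine. They also leave open how far the number depends on chain length, which a shorter propyl or a longer hexyl chain on the carbonyl carbon would address.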